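The compounds below may be only part of what the source reports. "The series", "measured", "known", "first", "only" and "open" are said of these compounds alone.

For the measured compounds named here, in a functional assay on U-937 cells (Homo sapiens) for antagonist activity, read by calcium flux (on this read-out higher numbers stand for weaker inhibition and lower numbers for stronger inhibition), only two compounds have numbers so far. Compound 1 (`COc1ccc(CCCCCCCCOc2ccc(C[S+]([O-])c3cccc(NS(=O)(=O)c4ccccc4)c3)nc2/C=C/C(=O)O)cc1`) gives 150 nM while compound 2 (`COc1ccc(CCCCCCCCOc2ccc(COc3cccc(C(=O)O)c3)[n+]([O-])c2/C=C/C(=O)O)cc1`) gives 890 nM so compound 1 holds the lower of the two numbers, by a gap beyond the usual scatter, and is the stronger inhibitor of the pair. These two differ in more than one place, so their gap cannot be tied to any single group.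

Compound 3 (`COc1ccc(CCCCCCCCOc2ccc(C[S+]([O-])c3cccc(CS(=O)(=O)C(F)(F)F)c3)nc2/C=C/C(=O)O)cc1`) keeps the core of compound 1 and changes one substituent: ((trifluoromethyl)sulfonyl)methyl in place of (phenylsulfonyl)amino on an aromatic carbon. Going by the values given here, the incoming group has no ring, and no measured pair isolates an exchange of this kind, so the data offer no direct guide. The expectation therefore starts from compound 1 at 150 nM and allows a wide margin on both sides. In this assay a slight weakening is expected, within the scatter or close to its edge. The expected step is a 1.5-fold higher number from compound 1 to compound 3 (0.17 log units; within the scatter) and its direction remains uncertain. Compound 3 is estimated at 220 nM with 60 nM to 800 nM as the expected range.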

Compound 3, half-maximal inhibitory concentration: 550 nM
For compound 3 the middle estimate is 2.5-fold (0.40 log units) below the measured one; the range from low to high includes it.
By their numbers in this assay, from the lowest: compound 1; then compounds 3 and 2 (each within the scatter of the next).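

In this assay, the exchange of (phenylsulfonyl)amino for ((trifluoromethyl)sulfonyl)methyl on this aromatic carbon gives a 3.7-fold higher number from compound 1 to compound 3 (0.56 log units; beyond the scatter), the first gap in this set that can be tied to a single place, and it shows that the group held here, meta to a large group, affects inhibition. The weakening is modest, so the aromatic ring and the hydrogen-bond donor of (phenylsulfonyl)amino, both absent from the incoming group, are not needed for compound 3 to retain measurable inhibition at 550 nM. No independent measurement shows what lies behind this step, and the exchange alters several features at once, so none of them can be singled out.

The compounds shown do not separate the loss of the ring from the loss of the donor, a question that (phenylsulfonyl)methyl or ((trifluoromethyl)sulfonyl)amino at this place would address directly. As far as these compounds go, how a smaller group, such as a carboxylic acid or a simple amine, would fare on this aromatic carbon also remains open, as does whether the step would hold on a different core.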